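Chalcone benzylamine series: lengthening the amine chain

The source may report more compounds than this note shows. Statements on the series, on what has been measured and on what is new or still open speak of the compounds shown alone.

Among the compounds with values here, compound 2 `CCN(C)Cc1c(OC)cc(OC)c(C(=O)/C=C/c2ccccc2Cl)c1O` gives 1300 nM in a functional assay on A549 cells (Homo sapiens) for antiproliferative activity, with a stated time of 72 h; on this read-out lower numbers stand for stronger inhibition and higher numbers for weaker inhibition; this is the lowest of the two numbers so far, the nearest being compound 1 `COc1cc(OC)c(C(=O)/C=C/c2ccccc2Cl)c(O)c1CN1CCCCC1`, which in this assay gives 2800 nM. Within the data shown here, the single step between the measured pair, a 2.2-fold lower number from compound 1 to compound 2 (0.33 log units; beyond the scatter), concerns which amine sits on the saturated chain carbon, and it is the only comparison available.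

Compound 3 `COc1cc(OC)c(C(=O)/C=C/c2ccccc2Cl)c(O)c1CN(C)CCCN(C)C` differs from compound 2 by (dimethylamino)methyl in place of hydrogen on a saturated chain carbon, two bonds along the chain from an amine nitrogen. Among the measured compounds shown here, no measured pair alters this position, so the earlier step bears on it only loosely: swapping the amine substituent moved the read-out modestly, and a further extension of the chain by a (dimethylamino)methyl group is expected to produce a step of similar or smaller size, if any, beyond the scatter. Compound 3 is therefore expected to give about 1000 nM in this assay, with a range from 400 nM to 2600 nM to allow for movement in either direction. The estimated step is a 1.3-fold lower number from compound 2 to compound 3 (0.11 log units; within the scatter).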

Compound 3, half-maximal inhibitory concentration: 3100 nM
Compound 3: middle estimate off by 3.1-fold (0.49 log units), on the low side; measured number outside the range, above it.
By their numbers in this assay, from the lowest: compound 2; then compounds 1 and 3 (each within the scatter of the next).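

In this assay, (dimethylamino)methyl in place of hydrogen on a saturated chain carbon, two bonds along the chain from an amine nitrogen, gives a 2.4-fold higher number from compound 2 to compound 3 (0.38 log units; beyond the scatter), so this position responds to the change and the extended chain does not keep the lower number of compound 2. Set against the piperidin-1-yl amine, (3-(dimethylamino)propyl)(methyl)amino gives a 1.1-fold higher number from compound 1 to compound 3 (0.04 log units; within the scatter), so an open-chain amine does not by itself separate a compound from compound 1, and of the three only compound 2 stands apart from both others. Nothing available accounts for the size or direction of the step from the added group.

The compounds shown leave open how the number changes along the chain, for instance with a 2-(dimethylamino)ethyl group or a chain longer than 3-(dimethylamino)propyl on the same amine nitrogen. They also leave open whether the step follows the dimethylamino group itself or the added chain length, which a morpholin-4-yl group or a plain butyl chain in its place could help to separate.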